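Side chain at the benzylic amide carbon: methoxymethyl analogue

The source may hold more compounds than are shown below. What is called first, only, known or untested is meant among the compounds shown, and "the series" means these compounds.

Measured so far in a functional assay on HEK293 cells for negative allosteric modulation of metabotropic glutamate receptor 5 (Homo sapiens), read by HTRF and inositol phosphate accumulation; a lower number here means a stronger inhibitor, a higher number a weaker inhibitor:
compound 1 `CCC[C@H](NC(=O)c1nccs1)c1cnc(Nc2ccc(C)nc2)c(Cl)c1` gives 978 nM
compound 2 `Cc1ccc(Nc2ncc([C@@H](NC(=O)c3nccs3)C(C)C)cc2Cl)cn1` gives 1060 nM
compound 3 `Cc1ccc(Nc2ncc([C@H](NC(=O)c3nccs3)C(C)C)cc2Cl)cn1` gives 7.5 nM

Compound 2 stands at the high end of the three numbers in this assay. Compound 1 sits within the scatter of it, the step of a 1.1-fold higher number from compound 1 to compound 2 (0.03 log units; within the scatter) being the swap of propyl for isopropyl. Compound 3 is far removed: the step of a 140-fold lower number from compound 2 to compound 3 (2.15 log units; beyond the scatter) is the largest change in the set, and it rests on (the fact that compounds 2 and 3 differ only in the configuration as drawn), so the configuration at the saturated chain carbon, not the side chain itself, carries the potency difference.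

Compound 4 `COC[C@H](NC(=O)c1nccs1)c1cnc(Nc2ccc(C)nc2)c(Cl)c1` is not yet measured. It keeps the configuration drawn for compound 2 and differs only in methoxymethyl in place of isopropyl on a saturated chain carbon bound to an amide-type nitrogen and an aromatic carbon. Among the compounds with values here, the one step that bears on it is a 1.1-fold higher number from compound 1 to compound 2 (0.03 log units; within the scatter), in which exchanging one three-carbon chain for another at this carbon left this assay unchanged within the scatter; methoxymethyl is an untested side chain here, so the outcome is less certain. The expectation for compound 4 is therefore a step of a 1.1-fold higher number from compound 2 to compound 4 (0.05 log units; within the scatter), none beyond the scatter. Compound 4 is estimated at 1200 nM, with a range of 400 nM to 4000 nM.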

Compound 4, half-maximal inhibitory concentration: 55.9 nM
Compound 4: middle estimate off by 21-fold (1.33 log units), on the high side, outside the stated range (below it).
By their numbers in this assay, from the lowest: compound 3; then compound 4; then compounds 1 and 2 (each within the scatter of the next).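

In this assay the propyl and isopropyl side chains of compounds 1 and 2 lie within the scatter of each other, so this carbon gave no sign of responding to its side chain in that drawn configuration. Methoxymethyl shows that it does respond: the change gives a 19-fold lower number from compound 2 to compound 4 (1.28 log units; beyond the scatter) and, against the propyl compound, a 17-fold lower number from compound 1 to compound 4 (1.24 log units; beyond the scatter), both beyond the scatter, even though isopropyl and methoxymethyl each hold 3 heavy atoms and the exchange mainly introduces 1 hydrogen-bond acceptor. The compounds shown establish the size of this gain, but nothing measured here explains it.

Within the data shown here, open is whether methoxymethyl brings a similar gain in the opposite configuration, the one drawn for compound 3, where the isopropyl side chain already reads far lower than in compound 2. Also open, from the compounds shown here alone, is whether the ether oxygen itself is what matters, a question that hydroxymethyl, ethoxymethyl or aminomethyl at the same carbon would address.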